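Dithiocarbamate chromone series: amine variation at the thiocarbonyl

The source may report more compounds than this note shows. Statements on the series, on what has been measured and on what is new or still open speak of the compounds shown alone.

Measured so far in a functional assay on SW480 cells (Homo sapiens) for antiproliferative activity, read by MTT assay, with a stated time of 72 h; a higher number here means a weaker inhibitor, a lower number a stronger inhibitor:
compound 1 `Cc1ccc2c(=O)c(CSC(=S)N3CCCCC3)coc2c1` gives > 25000 nM;
compound 2 `O=c1c(CSC(=S)N2CCCC2)coc2ccccc12` gives 2300 nM;
compound 3 `CC(C)N(C(=S)SCc1coc2ccccc2c1=O)C(C)C` gives 6800 nM.

The value of compound 1 is a limit of this assay, not a number. Among the two numbers, compound 3 stands highest; its nearest neighbour is compound 2, and the only measured step, a 3.0-fold higher number from compound 2 to compound 3 (0.47 log units; beyond the scatter), runs against compound 3.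

Compound 4 `O=c1c(CSC(=S)N2CCCCC2)coc2ccccc12` has not been measured. It differs from compound 3 as follows: piperidin-1-yl in place of diisopropylamino on a thiocarbonyl carbon. Within the data shown here, the one step that bears on this change, a 3.0-fold higher number from compound 2 to compound 3 (0.47 log units; beyond the scatter), shows that exchanging a cyclic amine for the open diisopropylamino raised the number. Compound 4 returns to a cyclic amine, piperidin-1-yl, so a move back towards the number of compound 2 is expected, of modest size; the expected step is a 1.7-fold lower number from compound 3 to compound 4 (0.23 log units; within the scatter). For compound 4 the estimate in this assay is 4000 nM, with a range from 1500 nM to 12000 nM.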

Compound 4, half-maximal inhibitory concentration: 1200 nM
For compound 4 the middle estimate is 3.3-fold (0.52 log units) above the measured one; the measured number lies below the stated range.
By their numbers in this assay, from the lowest: compounds 4 and 2 (each within the scatter of the next); then compound 3. At a limit, above all of these: compound 1.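

In this assay the open diisopropylamino is now set against two cyclic amines rather than one: a 5.7-fold lower number from compound 3 to compound 4 (0.75 log units; beyond the scatter) with piperidin-1-yl on the thiocarbonyl carbon, matching the direction seen with pyrrolidin-1-yl in compound 2. Ring size does not separate the two cyclic amines, since a 1.9-fold lower number from compound 2 to compound 4 (0.28 log units; within the scatter) gives no order between them. With the amine held as piperidin-1-yl, the series also gains its first reading away from the thiocarbonyl carbon: an at least 20-fold lower number from compound 1 to compound 4 (1.31 log units; beyond the scatter) shows that the aromatic carbon bearing methyl in compound 1 matters more than any amine change shown.

On these data alone, whether morpholin-4-yl or the smaller open dimethylamino would keep the number of compounds 2 and 4 remains open. The true size of the methyl step also remains open, as compound 1 gives a limit and not a number: the limit of > 25000 nM in this assay, at which 1 of the 4 values shown sits.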